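The source may report more compounds than this note shows. Statements on the series, on what has been measured and on what is new or still open speak of the compounds shown alone.

Measured so far in an ADME assay on HepG2 cells (Homo sapiens) for cytotoxicity, with a stated time of 72 h; a higher number here means that more compound is needed for the effect, a lower number that less compound is needed:
compound 1, `Cc1cc(NC(=O)Nc2ccc(C(C)(C)C)cc2)c2ccccc2n1`: 17000 nM.
compound 2, `Cc1cc(NC(=O)Nc2ccc(Cl)cc2)c2ccccc2n1`: > 25000 nM.
compound 3, `Cc1cc(NC(=O)Nc2cccc(Cl)c2)c2ccccc2n1`: 19000 nM.

For compound 2 the reading is a limit of the assay, not a number; it sits at the limit of > 25000 nM in this assay, at which 1 of the 3 values shown sits. Compound 1 differs from compound 2 by tert-butyl in place of chloro on an aromatic carbon, and the step is an at least 1.4-fold lower number from compound 2 to compound 1 (0.16 log units; that floor lies within the scatter). Compound 3 differs from compound 2 by 3-chlorophenyl in place of 4-chlorophenyl on an amide-type nitrogen, with an at least 1.3-fold lower number from compound 2 to compound 3 (0.11 log units; that floor lies within the scatter). Compound 1 and compound 3 lie within the scatter of each other.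

Compound 4, `Cc1cc(NC(=O)Nc2cccc(C(C)(C)C)c2)c2ccccc2n1`, is not yet measured in this assay. It differs from compound 3 by tert-butyl in place of chloro on an aromatic carbon. This is the same kind of change as from compound 2 to compound 1, but there the group sits para to a large group, here meta to a large group. Resting on the step from compound 2 to compound 1, an at least 1.4-fold lower number from compound 2 to compound 1 (0.16 log units; that floor lies within the scatter), whose floor lies within the scatter, the expected step is a 1.3-fold lower number from compound 3 to compound 4 (0.10 log units; within the scatter). The estimate for compound 4 is 15000 nM, expected between 7000 nM and 30000 nM.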

Compound 4, half-maximal effective concentration: > 25000 nM
Compound 4: a limit, no number; the forecaster's own chance of this, stated with the estimate: 25%; middle value at least 1.6-fold (0.22 log units) away from the limit.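

In this assay compound 4 reads > 25000 nM, which is a limit of the assay and not a number. Tert-butyl in place of chloro gives an at least 1.3-fold higher number from compound 3 to compound 4 (0.11 log units; that floor lies within the scatter), so the compounds shown neither establish that this change carries from one core to the other nor establish that it behaves differently: the same change on two cores in this assay, an at least 1.4-fold lower number (0.16 log units; that floor lies within the scatter) from compound 2 to compound 1 and an at least 1.3-fold higher number (0.11 log units; that floor lies within the scatter) from compound 3 to compound 4; the limit leaves it open whether they differ Both steps are floors, so no size for the change can be given on either core.

The compounds shown leave open how far compound 2 and compound 4 lie from the limit: the limit of > 25000 nM in this assay, at which 2 of the 4 values shown sit. Also open is whether an amine or a carboxylic acid in place of chloro on the same aromatic carbon would give a number within the range of this assay.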